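The compounds below may be only part of what the source reports. "The series", "measured", "known", "first", "only" and "open" are said of these compounds alone.

Compound 1 `Cn1nc2c(=O)n(CC3(O)CCN(Cc4ccc(-n5ccnc5)cc4Cl)CC3)cnc2c1-c1ccc(CN)cc1` and compound 2 `Cn1nc2c(=O)n(CC3(O)CCN(Cc4ccc(-c5cccs5)cc4Cl)CC3)cnc2c1-c1ccc(CN)cc1` share one core and differ in a single group on an aromatic carbon. In an assay on isolated protein for inhibition of ubiquitin carboxyl-terminal hydrolase 7 (Homo sapiens), with stated times of 30 min and 2 h (a lower number here means a stronger inhibitor, a higher number a weaker inhibitor), compound 1 gives 228 nM. In this assay compound 2 gives 38.6 nM. For the measured compounds named here, the change between them, a 5.9-fold lower number from compound 1 to compound 2 (0.77 log units; beyond the scatter), is the only measured step in the set. On the numbers shown, compound 2 holds the lowest value of the two, and compound 1 is its nearest neighbour, separated from it by more than the usual scatter.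

Compound 3 `Cc1ccc(-c2ccc(CN3CCC(O)(Cn4cnc5c(-c6ccc(CN)cc6)n(C)nc5c4=O)CC3)c(Cl)c2)s1` differs from compound 2 in one place: methyl in place of hydrogen on an aromatic carbon. Going by the values given here, no measured step concerns a methyl entering a five-membered aromatic ring; the single measured step, a 5.9-fold lower number from compound 1 to compound 2 (0.77 log units; beyond the scatter), exchanged one whole ring for another, which is a different kind of change. The size of the step to expect in this assay therefore cannot be read from any precedent here, and the most likely outcome is a step that stays within the scatter, in either direction. Compound 3 is accordingly estimated at 35 nM, within a range of 12 nM to 110 nM. The step this estimate implies, a 1.1-fold lower number from compound 2 to compound 3 (0.04 log units; within the scatter), is expected to remain within the scatter.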

Compound 3, half-maximal inhibitory concentration: 101 nM
Beside the measured number, compound 3's estimate is 2.9-fold (0.46 log units) below it, and the stated range covers the measured number.
By their numbers in this assay, from the lowest: compound 2; then compound 3; then compound 1.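

Putting methyl in place of hydrogen on the aromatic carbon next to the ring sulfur gives a 2.6-fold higher number from compound 2 to compound 3 (0.42 log units; beyond the scatter) in this assay, so this carbon of the five-membered aromatic ring responds to the addition of a single carbon atom, and the response is a loss rather than a gain. The 5-methylthiophen-2-yl group still compares favourably with 1H-imidazol-1-yl, with a 2.3-fold lower number from compound 1 to compound 3 (0.35 log units; beyond the scatter), so part of the advantage seen with thiophen-2-yl survives the added methyl, though a smaller part than before. Nothing measured alongside these numbers accounts for the loss, and the reason for it remains unknown.

The compounds shown carry only hydrogen or methyl on this carbon, so it remains open whether the loss belongs to methyl alone or extends to other groups there, such as a fluorine atom, a hydroxymethyl, an aminomethyl or a carboxylic acid. On these data alone, it also remains open whether a methyl on one of the other carbons of the thiophene ring would give a step of similar size or direction.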